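This account rests on a few compounds, and the source may have more. Where it says the series, first, only, none or still open, it means among the compounds named here.

In a physicochemical assay for lipophilicity (on this read-out lower numbers stand for lower lipophilicity and higher numbers for higher lipophilicity), compound 2 (`CC(C)c1cc(N(C)C)cc(C(C)C)c1O`) stands highest of the two measured compounds at 4.52, while compound 1 (`COS(=O)(=O)c1cc(C(C)C)c(O)c(C(C)C)c1`) gives 3.7. The next change leads to compound 3 (`CC(C)c1cc(NS(C)(=O)=O)cc(C(C)C)c1O`): methanesulfonamido in place of dimethylamino on an aromatic carbon. It places methanesulfonamido in place of dimethylamino on an aromatic carbon, para to a hydroxy group. Within the data shown here, only one measured step bears on this: a number 0.82 log units higher from compound 1 to compound 2 (beyond the scatter), a modest step beyond the scatter, with dimethylamino in place of methoxysulfonyl. The new change removes dimethylamino again, so a step of similar or somewhat larger size, in the downward direction, is expected. Among the measured compounds shown here, no measured compound carries methanesulfonamido, so this expectation rests on a single step and stays loose. The expected move is a number 1.12 log units lower from compound 2 to compound 3 (beyond the scatter). For compound 3 the estimate is 3.4, with an expected range from 2.8 to 4.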

Compound 3, partition coefficient: 3.14
Beside the measured number, compound 3's estimate is 0.26 log units above it; measured number inside the range.
By their numbers in this assay, from the lowest: compound 3; then compound 1; then compound 2.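

Notes on the position para to a hydroxy group: in this assay this aromatic carbon now has three substituents to compare, and methanesulfonamido sits lowest, with a number 1.38 log units lower from compound 2 to compound 3 (beyond the scatter). The two sulfonyl-containing groups do not read alike on this carbon, as methanesulfonamido replacing methoxysulfonyl gives a number 0.56 log units lower from compound 1 to compound 3 (beyond the scatter). No evidence at hand bears on why the read-out moves in this way.

Open, going by these compounds, is how a simple primary amine, a carboxylic acid or an acetamido group would rank against these three substituents on the same carbon. Also open, on these data alone, is whether the sulfonamide nitrogen hydrogen matters, a question that the matching methyl-capped sulfonamide could address, and whether longer chains on sulfur extend or reverse the steps seen here.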